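Exchanging the aryl group on the thiazole of a CXCR3 inhibitor

A few compounds are considered here, and "the series" means these few. Any claim that something is new, unique, unknown or untested is made for them only; others in the source may bear on it.

Compound 3, with the structure `Cc1nc(C)n(CC(=O)N2CCN(c3sc(C(F)(F)F)nc3-c3cnc(OC(C)C)nc3)C[C@H]2C)n1`, gives 216 nM in an assay on blood for inhibition of C-X-C chemokine receptor type 3 (Homo sapiens), with a stated time of 30 min (a lower number here means a stronger inhibitor, a higher number a weaker inhibitor), and stands highest among the three measured numbers. Compound 2 (`CCOc1ncc(-c2nc(C(F)(F)F)sc2N2CCN(C(=O)Cn3ccc(C(F)(F)F)n3)[C@H](C)C2)cn1`) gives 90 nM, and compound 1 (`CCOc1ncc(-c2nc(C(F)(F)F)sc2N2CCN(C(=O)Cn3nc(C)cc3C)[C@H](C)C2)cn1`) gives 60 nM. Compound 4 (`COc1ccc(-c2nc(C(F)(F)F)sc2N2CCN(C(=O)Cn3nc(C)nc3C)[C@H](C)C2)cn1`) is the same as compound 3 except for one change: 6-methoxypyridin-3-yl in place of 2-isopropoxypyrimidin-5-yl on an aromatic carbon. Within the data shown here, the only measured step that changes a single group is a 1.5-fold higher number from compound 1 to compound 2 (0.18 log units; within the scatter), which concerns the group on the saturated chain carbon bound to the carbonyl carbon and not the aromatic group at the thiazole carbon; it therefore does not bear on this change. Among the measured compounds shown here, no pair of measured compounds differs only in the aryl group, so the data give no direct guide to its size or direction. He therefore expects compound 4 to show 250 nM with a range from 80 nM to 800 nM, a step of a 1.2-fold higher number from compound 3 to compound 4 (0.06 log units; within the scatter), an estimate that stays close to compound 3 and carries wide uncertainty.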

Compound 4, half-maximal inhibitory concentration: 1580 nM
For compound 4 the middle estimate is 6.3-fold (0.80 log units) below the measured one; the measured number lies above the stated range.
By their numbers in this assay, from the lowest: compounds 1 and 2 (each within the scatter of the next); then compound 3; then compound 4.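

Among these compounds, exchanging 2-isopropoxypyrimidin-5-yl for 6-methoxypyridin-3-yl gives a 7.3-fold higher number from compound 3 to compound 4 (0.86 log units; beyond the scatter) in this assay, so the inhibitor's number clearly depends on which aryl group stands at this aromatic carbon, something no earlier pair could show. The exchange alters the aromatic ring, with 1 hetero atom in place of 2, and the ether chain at the same time, so the step belongs to the whole group and cannot be divided between these two parts. Nothing measured here explains why the number rises.

On these data alone, it remains open whether a methoxy group on the ring of the leaving group, or an isopropoxy group on the ring of the entering one, would recover the lost inhibition. As far as these compounds go, it is also open how an amine on either ring would fare.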